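This account rests on a few compounds, and the source may have more. Where it says the series, first, only, none or still open, it means among the compounds named here.

Two compounds in this set share a core built from a pyrazole-linked enone, and both have been tested in a functional assay on SF-539 cells (Homo sapiens) for inhibition, read by sulforhodamine B assay, with a stated time of 48 h; on this read-out lower numbers stand for higher toxicity in this test and higher numbers for lower toxicity in this test. Compound 1, `COc1ccc(-c2cc(/C=C/C(=O)c3ccc(N)cc3)[nH]n2)cc1`, gives 8250 nM in this assay. Compound 2, `COc1cc(-c2cc(/C=C/C(=O)c3ccc(Cl)c(Cl)c3)[nH]n2)cc(OC)c1OC`, gives 57800 nM in this assay. Of the two numbers, compound 2 has the higher one, and the gap to compound 1 lies beyond the usual scatter of the test, so compound 2 reads as clearly less toxic here.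

Compound 3, `COc1ccc(C(=O)/C=C/c2cc(-c3cc(OC)c(OC)c(OC)c3)n[nH]2)cc1`, has not yet been measured in this assay. It differs from compound 2 in one place: 4-methoxyphenyl in place of 3,4-dichlorophenyl on a carbonyl carbon. Going by the values given here, no measured pair shows exactly this exchange, so any expectation rests only on the two numbers above. Compound 1, which carries an aminophenyl on that same carbonyl, lies well below compound 2, which hints that a smaller, single-substituent phenyl on the carbonyl may go with a lower number. The step from compound 2 to compound 3 is therefore expected to be downward, a 2.9-fold lower number from compound 2 to compound 3 (0.46 log units; beyond the scatter), though with wide uncertainty. On that basis compound 3 is estimated at 20000 nM, within a range of 6000 nM to 70000 nM.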

Compound 3, concentration lethal to 50% of the cells: 5850 nM
For compound 3 the middle estimate is 3.4-fold (0.53 log units) above the measured one, and the stated range ends above it.
By their numbers in this assay, from the lowest: compounds 3 and 1 (each within the scatter of the next); then compound 2.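

In this assay, putting 4-methoxyphenyl in place of 3,4-dichlorophenyl on a carbonyl carbon gives a 9.9-fold lower number from compound 2 to compound 3 (0.99 log units; beyond the scatter), with the rest of the molecule unchanged. This pair therefore shows that the group at this position can, on its own, shift the result toward higher toxicity in this test, something the earlier pair could not show because its two compounds differ in more than one place. Both groups have 8 heavy atoms and one six-membered aromatic ring, so the exchange leaves those counts unchanged and swaps two chlorine atoms for a methoxy group with one hydrogen-bond acceptor, but no measurement here connects any of these differences to the step.

This single exchange leaves open whether phenyl without a substituent, 4-chlorophenyl or 4-hydroxyphenyl at this position would give a number closer to that of compound 2 or of compound 3, which would help separate the loss of the chlorine atoms from the gain of the methoxy group. It also leaves open whether the same exchange would produce a step of similar size on the core of compound 1, which has a single methoxy group on its other phenyl ring.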